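Aryl versus Arylpropyl on a Ring Amine Nitrogen

The source may hold more compounds than are shown below. What is called first, only, known or untested is meant among the compounds shown, and "the series" means these compounds.

Measured compounds:
compound 1, `Nc1scc(CN2CCN(c3cccnc3)CC2)c1C(=O)c1ccc(Cl)cc1`, 0%
compound 2, `Nc1scc(CN2CCN(CCCc3ccc(Cl)cc3)CC2)c1C(=O)c1ccc(Cl)cc1`, 0%
compound 3, `Nc1scc(CN2CCN(c3cccc(Cl)c3)CC2)c1C(=O)c1ccc(Cl)cc1`, not yet measured

In an assay on CHO cells for displacement of a labelled ligand from adenosine receptor A3 (Homo sapiens), read by scintillation counting, with a stated time of 120 min, tested at 10 uM (a lower number here means less inhibition, a higher number more inhibition at the concentration tested (going by the name of the read-out)), compound 1 gives 0%. Compound 2, in which 3-(4-chlorophenyl)propyl replaces pyridin-3-yl on an amine nitrogen in a ring, gives 0% in this assay, so that the step of no change at the digits printed from compound 1 to compound 2 (within the scatter) shows no change within the scatter. Compound 2 therefore stands level with compound 1 at the digits given; neither shows measurable inhibition at the concentration tested.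

Compound 3 differs from compound 2 as follows: 3-chlorophenyl in place of 3-(4-chlorophenyl)propyl on an amine nitrogen in a ring. For the measured compounds named here, the only measured step that bears on this change is no change at the digits printed from compound 1 to compound 2 (within the scatter), which replaced one group on the same ring nitrogen by another and brought no movement in this assay. Going by the values given here, with both measured compounds at the same level and the only known step flat, the step expected from compound 2 to compound 3 is no change at the digits printed from compound 2 to compound 3 (within the scatter), that is, none beyond the scatter. Compound 3 is thus estimated to give 0% in this assay, within the range -8% to 12%.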

Compound 3, a percentage reported as inhibition, at one concentration (the size of the read-out at that concentration, not a potency): 1%
For compound 3 the middle estimate is 1 percentage points below the measured one; the measured number falls inside the stated range.
By their numbers in this assay, from the lowest: compounds 1, 2 and 3 (each within the scatter of the next).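

In this assay, replacing 3-(4-chlorophenyl)propyl with 3-chlorophenyl on the amine nitrogen in the ring gives a number 1 percentage points higher from compound 2 to compound 3 (within the scatter), and replacing pyridin-3-yl with 3-chlorophenyl gives a number 1 percentage points higher from compound 1 to compound 3 (within the scatter). The earlier pair had compared only a pyridin-3-yl group with a chlorophenyl group carried on a propyl chain, whereas compound 3 adds a chlorophenyl group without that chain, so all three groups at this position now stand within the scatter of one another. Nothing available accounts for this flat result or shows how these compounds behave in any other setting.

All three readings lie close to zero at a single concentration, so they do not show whether any of these groups could be told apart under other conditions, or whether any group on this nitrogen can raise the number at all. On these data alone, whether a benzyl group, an acetyl group or a chain ending in a carboxylic acid on the same nitrogen would leave the reading where it stands remains open, as does the effect of replacing the 4-chlorophenyl group on the carbonyl of the shared core.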